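Oxytocin receptor series: amide variation at the carbonyl of compound 1

This account rests on a few compounds, and the source may have more. Where it says the series, first, only, none or still open, it means among the compounds named here.

Measured compounds:
compound 1 `CCC(CC)[C@@H]1C(=O)N[C@H](C2Cc3ccccc3C2)C(=O)N1[C@@H](C(=O)N1CCOCC1)c1ccc(C)nc1`, 0.0251 nM
compound 2 `Cc1ccc([C@H](C(=O)N2CCOCC2)N2C(=O)[C@@H](C3Cc4ccccc4C3)NC(=O)[C@H]2CC2CC2)cn1`, 5.01 nM
compound 3 `CCC(CC)[C@@H]1C(=O)N[C@H](C2Cc3ccccc3C2)C(=O)N1[C@@H](C(=O)N1CCOCC1)c1ccc(C)nc1C`, 0.0316 nM

In an assay on isolated protein for displacement of a labelled ligand from Oxytocin receptor (Homo sapiens) (on this read-out higher numbers stand for weaker inhibition and lower numbers for stronger inhibition), compound 1 gives the lowest number of the three. Compound 3 sits close to it, with a 1.3-fold higher number from compound 1 to compound 3 (0.10 log units; within the scatter); compound 2 lies far away, with a 200-fold higher number from compound 1 to compound 2 (2.30 log units; beyond the scatter).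

Compound 4 `CCC(CC)[C@@H]1C(=O)N[C@H](C2Cc3ccccc3C2)C(=O)N1[C@@H](C(=O)N(C)C)c1ccc(C)nc1` differs from compound 1 by dimethylamino in place of morpholin-4-yl on a carbonyl carbon. For the measured compounds named here, no measured step touches this carbonyl-attached group, so neither step bears directly on it. The change on the saturated ring carbon was large, the change on the aromatic carbon was not; the present change is of neither kind. With no guide in the data, only a small loss is expected, a 2.5-fold higher number from compound 1 to compound 4 (0.40 log units; beyond the scatter). Compound 4 is therefore estimated at 0.063 nM, with a range from 0.015 nM to 0.3 nM.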

Compound 4, inhibition constant: 0.0501 nM
The estimate for compound 4 lay 1.3-fold (0.10 log units) above the measured number, within the range that was stated.
By their numbers in this assay, from the lowest: compounds 1, 3 and 4 (each within the scatter of the next); then compound 2.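

In this assay, replacing morpholin-4-yl with dimethylamino on the carbonyl carbon gives a 2.0-fold higher number from compound 1 to compound 4 (0.30 log units; within the scatter) and so leaves the number within the scatter. At this position, neither the six-membered ring nor its oxygen is needed to stay level with compound 1, a contrast to the large step on the saturated ring carbon. Nothing at hand accounts for this result.

Still open, on these data alone, is how far this tolerance extends: whether piperidin-1-yl or 4-methylpiperazin-1-yl, or a smaller unsubstituted amino group, would hold the number. For the compounds shown here, the dimethylcarbamoyl group has also been seen only with pentan-3-yl on the saturated ring carbon.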